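Solubility of Quinoline Ureas: From Fluoro to Acetyl

A few compounds are considered here, and "the series" means these few. Any claim that something is new, unique, unknown or untested is made for them only; others in the source may bear on it.

Compound 2 `Cc1cc(NC(=O)Nc2ccc(F)cc2)c2ccccc2n1` is a urea that links the shared core to a benzene ring bearing fluoro. In a physicochemical assay for solubility, at pH 7.4 (on this read-out lower numbers stand for lower solubility and higher numbers for higher solubility), compound 2 gives 3700 nM, the lower of the two numbers in hand. Among the compounds with values here, its only measured neighbour, compound 1 `Cc1cc(NC(=O)Nc2ccc(C(=O)O)cc2)c2ccccc2n1`, carries carboxy instead of fluoro, and in this assay compound 1 gives 9300 nM. The step of a 2.5-fold lower number from compound 1 to compound 2 (0.40 log units; beyond the scatter) shows that a swap at this position moves solubility by a modest amount.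

Compound 3 `CC(=O)c1ccc(NC(=O)Nc2cc(C)nc3ccccc23)cc1` is the next variant: acetyl in place of fluoro on an aromatic carbon. Within the data shown here, no measured step involves acetyl, so the carboxy-to-fluoro step is the only guide, and it was modest. Acetyl brings 1 hydrogen-bond acceptor, so a number a little above that of compound 2 is expected, possibly still within the scatter. The expected step is a 1.2-fold higher number from compound 2 to compound 3 (0.09 log units; within the scatter). Compound 3 is estimated at 4500 nM, within 1800 nM to 11000 nM.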

Compound 3, solubility: 3800 nM
The estimate for compound 3 lay 1.2-fold (0.07 log units) above the measured number; measured number inside the range.
By their numbers in this assay, from the lowest: compounds 2 and 3 (each within the scatter of the next); then compound 1.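

In this assay, the step of a 1.0-fold higher number from compound 2 to compound 3 (0.01 log units; within the scatter) shows that fluoro and acetyl cannot be told apart at this position, even though acetyl is the larger group and adds a hydrogen-bond acceptor. The step of a 2.4-fold lower number from compound 1 to compound 3 (0.39 log units; beyond the scatter) exchanges only the hydroxy of carboxy for methyl on the same carbonyl carbon, yet it is beyond the scatter. Among these three compounds, then, compound 1 with carboxy stands apart, while compound 2 and compound 3 stay together at a lower level. Nothing available here explains this difference.

As far as these compounds go, it remains open whether an amine or a longer chain at this position would fall with fluoro and acetyl or with carboxy. A single carboxy compound also cannot show whether other groups can reach its level.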